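Extending the benzyl ester of a dihydropyridine series

The compounds below may be only part of what the source reports. "The series", "measured", "known", "first", "only" and "open" are said of these compounds alone.

Measured compounds:
- compound 1 `CCCOC(=O)C1=C(C)NC(C)=C(C(=O)OCC)C1c1[nH]cnc1Cl`: 407 nM
- compound 2 `CCOC(=O)C1=C(C)NC(C)=C(C(=O)OCc2ccccc2)C1c1[nH]cnc1Cl`: 91.2 nM

In an assay on isolated protein for inhibition of Voltage-dependent L-type calcium channel subunit alpha-1C (Cavia porcellus) (on this read-out lower numbers stand for stronger inhibition and higher numbers for weaker inhibition), compound 2 gives the lowest of the two numbers; the nearest is compound 1, and the step of a 4.5-fold lower number from compound 1 to compound 2 (0.65 log units; beyond the scatter) lies beyond the scatter. That step was brought about by phenyl in place of ethyl on a saturated chain carbon bound to an oxygen next to a carbonyl group.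

Compound 3 `CCOC(=O)C1=C(C)NC(C)=C(C(=O)OCCc2ccccc2)C1c1[nH]cnc1Cl` differs from compound 2 by benzyl in place of phenyl on a saturated chain carbon bound to an oxygen next to a carbonyl group. For the measured compounds named here, the only measured step that touches this place is a 4.5-fold lower number from compound 1 to compound 2 (0.65 log units; beyond the scatter), which shows that a change of the ester group at this point can move this assay by a modest amount. Going by the values given here, no measured pair shows what lengthening the chain from benzyl to phenethyl does, so the direction is open. Compound 3 is therefore expected to stay close to compound 2, with a step of a 1.2-fold higher number from compound 2 to compound 3 (0.08 log units; within the scatter) that may well fall within the scatter. The estimate for compound 3 in this assay is 110 nM, with a range from 30 nM to 400 nM.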

Compound 3, half-maximal inhibitory concentration: 70.8 nM
For compound 3 the middle estimate is 1.6-fold (0.19 log units) above the measured one; low and high end bracket the measured number.
By their numbers in this assay, from the lowest: compounds 3 and 2 (each within the scatter of the next); then compound 1.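

In this assay, lengthening benzyl to phenethyl gives a 1.3-fold lower number from compound 2 to compound 3 (0.11 log units; within the scatter) and so leaves compound 2 and compound 3 within the scatter of each other. For the compounds shown here, this is the first sign that the read-out at this place does not separate these two chain lengths, at least when the chain ends in phenyl. The advantage over the shorter ester seen with compound 2 therefore also holds for the phenethyl ester, with a 5.7-fold lower number from compound 1 to compound 3 (0.76 log units; beyond the scatter) lying beyond the scatter and of the same modest size, so in these three compounds the phenyl-bearing esters stand apart from compound 1 whichever of the two chains carries the phenyl. Nothing available for these compounds accounts for why the two chains read alike.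

Going by these compounds, it remains open whether this level would hold with a longer chain such as 3-phenylpropyl, or whether it would move with an amine, a carboxylic acid or a methoxy group on the phenyl ring. Also open, on these data alone, is whether a phenethyl group would behave in the same way on the other ester of the core, where the ethyl group stands in compound 2 and compound 3.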